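Amide swap on the weakest compound: expectation

The compounds below may be only part of what the source reports. "The series", "measured", "known", "first", "only" and "open" are said of these compounds alone.

Compounds measured so far, with the number each gave in this assay:
compound 1 `O=C([C@@H]1CCCN(S(=O)(=O)c2ccc(S(=O)(=O)N3CC[C@@H](O)C3)cc2)C1)N1CCC(F)(F)CC1`: 330 nM
compound 2 `CC(C)S(=O)(=O)c1ccc(S(=O)(=O)N2CCC[C@@H](C(=O)N3CCC(F)(F)CC3)C2)cc1`: 50 nM
compound 3 `CCN(CC)S(=O)(=O)c1ccc(S(=O)(=O)N2CCC[C@@H](C(=O)NC3CCOCC3)C2)cc1`: 8570 nM

In a functional assay on BXPC-3 cells (Homo sapiens) for inhibition, read by MTT assay, with a stated time of 7 days (on this read-out higher numbers stand for weaker inhibition and lower numbers for stronger inhibition), compound 3 gives 8570 nM, the highest number of the three. The step to compound 4 `CCN(CC)S(=O)(=O)c1ccc(S(=O)(=O)N2CCC[C@@H](C(=O)N3CCC(C(F)F)CC3)C2)cc1` is 4-(difluoromethyl)piperidin-1-yl in place of (oxan-4-yl)amino on a carbonyl carbon. Going by the values given here, the one measured step, a 6.6-fold lower number from compound 1 to compound 2 (0.82 log units; beyond the scatter), sits elsewhere in the molecule and does not bear on this change. Compound 1 gives 330 nM and compound 2 gives 50 nM; both differ from compound 3 in more than one place, so their values only hint that a far lower number is reachable. A downward step is expected for compound 4, of moderate size: a 12-fold lower number from compound 3 to compound 4 (1.09 log units; beyond the scatter). Compound 4 is estimated at 700 nM, within 150 nM to 3500 nM.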

Compound 4, half-maximal inhibitory concentration: 450 nM
Beside the measured number, compound 4's estimate is 1.6-fold (0.19 log units) above it; low and high end bracket the measured number.
By their numbers in this assay, from the lowest: compound 2; then compounds 1 and 4 (each within the scatter of the next); then compound 3.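

At the carbonyl carbon, a 19-fold lower number from compound 3 to compound 4 (1.28 log units; beyond the scatter) comes with 4-(difluoromethyl)piperidin-1-yl in place of (oxan-4-yl)amino in this assay and shows that this position, untouched by the earlier step, strongly moves the read-out. The swap alters the ring hetero atom, the fluorine content and the hydrogen-bond donor and acceptor counts together, so the step cannot be assigned to any one of them. No measurement here explains the step. Open, as far as these compounds go, is how plain piperidin-1-yl or 4-methylpiperidin-1-yl would compare, and whether N-methyl(oxan-4-yl)amino, which lacks the amide hydrogen, would shift the number.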